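A few compounds are considered here, and "the series" means these few. Any claim that something is new, unique, unknown or untested is made for them only; others in the source may bear on it.

Compound 1 `O=C(NC(=S)N1CCc2c(OCCCCCOc3ccc(Cl)cc3)cccc21)C1CCCCC1`: > 50000 nM
Compound 2 `O=C(NC(=S)N1CCc2c(OCCCCCOc3ccc(Cl)cc3)cccc21)c1cccnc1`: 11100 nM
Compound 3 `O=C(NC(=S)N1CCc2c(OCCCCCOc3ccc(Cl)cc3)cccc21)c1ccno1`: 37100 nM

Of the compounds shown here, three built on one shared core have been tested in an ADME assay on Huh-7 cells (Homo sapiens) for cytotoxicity; on this read-out higher numbers stand for lower toxicity in this test and lower numbers for higher toxicity in this test. In this assay compound 1 gives > 50000 nM, which is a limit of the assay and not a number (the limit of > 50000 nM in this assay, at which 1 of the 3 values shown sits). In this assay compound 2 gives 11100 nM and compound 3 gives 37100 nM. Compound 3 thus holds the highest of the two numbers; the gap to the nearest, a 3.3-fold higher number from compound 2 to compound 3 (0.52 log units; beyond the scatter), reaches beyond the scatter. The step of an at least 4.5-fold lower number from compound 1 to compound 2 (0.65 log units; beyond the scatter) also reaches beyond the scatter, whereas an at least 1.3-fold lower number from compound 1 to compound 3 (0.12 log units; that floor lies within the scatter) has a floor that lies within it.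

Compound 4 `O=C(NC(=S)N1CCc2c(OCCCCCOc3ccc(Cl)cc3)cccc21)c1cc2ccccc2s1` has not yet been measured. It differs from compound 3 in that (1-benzothiophen-2-yl in place of 1,2-oxazol-5-yl on a carbonyl carbon). The measured steps that bear on such a swap on the carbonyl carbon are an at least 4.5-fold lower number from compound 1 to compound 2 (0.65 log units; beyond the scatter) and a 3.3-fold higher number from compound 2 to compound 3 (0.52 log units; beyond the scatter), both modest, both beyond the scatter, and pointing in opposite directions. A step of similar modest size toward a lower number is therefore expected, a 1.9-fold lower number from compound 3 to compound 4 (0.27 log units; within the scatter). For compound 4 the estimate in this assay is 20000 nM, with a range from 7000 nM to 50000 nM.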

Compound 4, half-maximal cytotoxic concentration: > 50000 nM
Compound 4 was reported as a limit (the forecaster's own chance of this, stated with the estimate: 15%); middle value at least 2.5-fold (0.39 log units) from the limit.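

In this assay compound 4 sits at a limit and not at a number, the second compound of the set to do so: the limit of > 50000 nM in this assay, at which 2 of the 4 values shown sit. With 1-benzothiophen-2-yl in place of pyridin-3-yl on the carbonyl carbon there is an at least 4.5-fold higher number from compound 2 to compound 4 (0.65 log units; beyond the scatter), so an aromatic ring at this position does not by itself go with a low number, and compound 2 is the only one of the four whose number is lower than all the others beyond the scatter. With 1-benzothiophen-2-yl in place of 1,2-oxazol-5-yl there is an at least 1.3-fold higher number from compound 3 to compound 4 (0.12 log units; that floor lies within the scatter), whose floor lies within the scatter, and the step between compound 1 and compound 4 cannot be read, since both are limits.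

As far as these compounds go, how compound 1, compound 3 and compound 4 truly rank against one another stays open, as the limits hide the real size of their differences. Also open, from the compounds shown here alone, is whether the lower number of compound 2 belongs to pyridin-3-yl alone, or would return with a plain phenyl, a pyridin-4-yl or a group carrying an amine or a carboxylic acid on the same carbonyl carbon.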